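A few compounds are considered here, and "the series" means these few. Any claim that something is new, unique, unknown or untested is made for them only; others in the source may bear on it.

Compound 3 `Cc1ccc(-c2nn(-c3ccc(F)cc3F)cc2CNCCN2CCN(C)CC2)cc1` was tested in an ADME assay on Huh-7 cells (Homo sapiens) for cytotoxicity; a higher number here means that more compound is tolerated, a lower number that less compound is tolerated. In that test compound 3 gave only the limit of the assay, > 20000 nM, so no exact number is known for it. Compound 1 `Cc1ccccc1CNc1nn(-c2ccc(F)cc2F)cc1CNCCN1CCN(C)CC1` likewise gave only a limit, > 20000 nM. Compound 2 `Cc1cccc(-c2nn(-c3ccc(F)cc3F)cc2CNCCN2CCN(C)CC2)c1` also gave only a limit, > 20000 nM. All three values thus sit at the limit of > 20000 nM in this assay, at which 3 of the 3 values shown sit. The steps among these compounds cannot be read: a step that the two limits leave unreadable from compound 1 to compound 2, a step that the two limits leave unreadable from compound 1 to compound 3, and a step that the two limits leave unreadable from compound 2 to compound 3. Compound 4 `CN1CCN(CCNCc2cn(-c3ccc(F)cc3F)nc2-c2cccc(Cl)c2)CC1` differs from compound 3 in one place: 3-chlorophenyl in place of 4-methylphenyl on an aromatic carbon. Going by the values given here, none of the measured steps exchanges a methylphenyl for a chlorophenyl at this place, and all of them are unreadable, so they give no size to expect for the step in this assay. What they do show is that three compounds of this series reached the same limit. For compound 4 the estimate is therefore 25000 nM, within 10000 nM to 60000 nM, most likely again reported as a limit. The expected step is a step that the limit leaves unreadable from compound 3 to compound 4.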

Compound 4, half-maximal cytotoxic concentration: 15000 nM
Compound 4: the middle estimate sits 1.7-fold (0.22 log units) above what was measured; low and high end bracket the measured number.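

In this assay, compound 4 gives the only exact number among these compounds, so this position now has one reading that is not a limit. Placing 3-chlorophenyl on this aromatic carbon gives an at least 1.3-fold lower number from compound 3 to compound 4 (0.12 log units; that floor lies within the scatter), and the other two comparisons give an at least 1.3-fold lower number from compound 2 to compound 4 (0.12 log units; that floor lies within the scatter) and an at least 1.3-fold lower number from compound 1 to compound 4 (0.12 log units; that floor lies within the scatter). Each of these is only a floor and does not establish a real change, because the other three compounds stop at a limit: the limit of > 20000 nM in this assay, at which 3 of the 4 values shown sit.

From the compounds shown here alone, how far the true values of compound 1, compound 2 and compound 3 lie from that of compound 4 remains open. A 4-chlorophenyl or a 3-methoxyphenyl group at this position could show whether the exact number here belongs to the chlorine or to where it sits on the phenyl ring.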